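The source may hold more compounds than are shown below. What is called first, only, known or untested is meant among the compounds shown, and "the series" means these compounds.

Compound 1, `O=S(=O)(/C=C/c1ccc(O)c(O)c1)Cc1ccccc1`, is the starting point of this small set. In a physicochemical assay for permeability, using PAMPA, with a stated time of 18 h, tested at 5 mg/mL (a lower number here means that the compound crosses the layer more slowly, a higher number that the compound crosses the layer faster), compound 1 gives 10.1 10^-6 cm/s. Compound 2, `O=S(=O)(/C=C/c1ccc(O)c(O)c1)Cc1ccc(Cl)cc1`, carries one change: chloro in place of hydrogen on an aromatic carbon. That change made a step of a 3.1-fold lower number from compound 1 to compound 2 (0.49 log units; beyond the scatter), and in this assay compound 2 gives 3.3 10^-6 cm/s.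

Compound 3, `[O-][S+](/C=C/c1ccc(O)c(O)c1)Cc1ccccc1`, shares the same catechol-bearing side but has a different core; how the two cores differ is not broken down here. In this assay compound 3 gives 4.9 10^-6 cm/s, a number that the two values show to be lower than that of compound 1, and one that sits within the usual scatter of the number for compound 2.

Compound 4, `[O-][S+](/C=C/c1ccc(O)c(O)c1)Cc1ccc(Cl)cc1`, has not yet been measured. It differs from compound 3 by chloro in place of hydrogen on an aromatic carbon, the same change that led from compound 1 to compound 2, placed in the same way. Because that earlier change gave a 3.1-fold lower number from compound 1 to compound 2 (0.49 log units; beyond the scatter), a step of similar size is expected here, a 2.7-fold lower number from compound 3 to compound 4 (0.43 log units; beyond the scatter). On that basis compound 4 is estimated to give about 1.8 10^-6 cm/s, most likely between 0.9 10^-6 cm/s and 3.5 10^-6 cm/s.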

Compound 4, apparent permeability: 4.1 10^-6 cm/s
The estimate for compound 4 lay 2.3-fold (0.36 log units) below the measured number; the whole stated range lies below it.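

In this assay, chloro in place of hydrogen on the aromatic carbon gave a 1.2-fold lower number from compound 3 to compound 4 (0.08 log units; within the scatter), whereas the same change on the core of compound 1 gave a 3.1-fold lower number from compound 1 to compound 2 (0.49 log units; beyond the scatter). The change therefore did not carry over from one core to the other at the same size: a step beyond the usual scatter on the core of compound 1 became, on the core of compound 3, a step that cannot be told apart from the differences seen between repeated measurements. Among these compounds, this rests on only one pair of compounds for each core, so it sets no general rule for the series, and nothing measured here explains why the two cores differ in this way.

The compounds shown leave open how another group in the same place, such as fluoro, methoxy or an amine, would behave on each core. They also leave open whether a carboxylic acid or a longer chain would give steps that match across the two cores.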